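Sulfonamide chain length in the anilide series: cytotoxicity notes

The compounds below may be only part of what the source reports. "The series", "measured", "known", "first", "only" and "open" are said of these compounds alone.

Measured so far:
Compound 1 `Cc1cc(NC(=O)c2ccc(C#N)cc2)ccc1NS(C)(=O)=O`: 171000 nM
Compound 2 `Cc1cc(NC(=O)c2cccc(C(F)(F)F)c2)ccc1NS(C)(=O)=O`: 110000 nM
Compound 3 `CCS(=O)(=O)Nc1ccc(NC(=O)c2ccc(C#N)cc2)cc1C`: 109000 nM

All three compounds were run in an ADME assay on RAW264.7 cells (Mus musculus) for cytotoxicity, read by MTT assay, with a stated time of 48 h; on this read-out higher numbers stand for weaker inhibition and lower numbers for stronger inhibition. In this assay compound 1 gives 171000 nM, compound 2 gives 110000 nM and compound 3 gives 109000 nM. The three numbers sit close together, and none of the gaps between them is beyond the scatter, so no order among them is claimed.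

Compound 1 and compound 3 share a core and differ in one place: methyl in place of hydrogen on a saturated chain carbon bound to a sulfonyl sulfur. That change gives a 1.6-fold lower number from compound 1 to compound 3 (0.20 log units; within the scatter). Compound 2 carries a different core; how the core of compound 2 differs from that of compound 1 is not broken down here.

Compound 4 `CCS(=O)(=O)Nc1ccc(NC(=O)c2cccc(C(F)(F)F)c2)cc1C` is not yet measured. It stands to compound 2 exactly as compound 3 stands to compound 1: methyl in place of hydrogen on a saturated chain carbon bound to a sulfonyl sulfur. The place of the change is the same in both pairs, so this is the same change made on a second core. For the measured compounds named here, the only guide to its size is the single earlier instance, and that step lay within the scatter. For compound 4 in this assay a step of about a 1.3-fold lower number from compound 2 to compound 4 (0.11 log units; within the scatter) is therefore expected, resting on compound 2 at 110000 nM and on the earlier step of a 1.6-fold lower number from compound 1 to compound 3 (0.20 log units; within the scatter). The estimate for compound 4 is 85000 nM, with an expected range from 40000 nM to 180000 nM.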

Compound 4, half-maximal inhibitory concentration: 114000 nM
Beside the measured number, compound 4's estimate is 1.3-fold (0.13 log units) below it, and the stated range covers the measured number.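

For the compounds shown here, on the core of compound 2, the change from methylsulfonyl to ethylsulfonyl gives a 1.0-fold higher number from compound 2 to compound 4 (0.02 log units; within the scatter) in this assay, so this instance, like the first, shows no step that can be told from repeated measurement. Set side by side, the two instances agree: the same change on two cores in this assay, a 1.6-fold lower number (0.20 log units; within the scatter) from compound 1 to compound 3 and a 1.0-fold higher number (0.02 log units; within the scatter) from compound 2 to compound 4, 1.6-fold (0.21 log units) apart, within the scatter of two such steps

Going by these compounds alone, this shows that, on these two cores, methyl in place of hydrogen on a saturated chain carbon bound to a sulfonyl sulfur leaves the number within the scatter, so the absence of a readable step carries from one core to the other; it does not show that the change is without any effect, gives no direction for the step, and with only two pairs says nothing about other cores.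

Still open, going by these compounds, is whether a longer chain such as propyl or butyl, or an amine or a cyclopropyl ring, in place of the ethyl group would give a step beyond the scatter in this assay. Also open, on these data alone, is whether the same change would read alike on a core carrying a carboxylic acid or a methoxy group in place of the nitrile or trifluoromethyl group.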